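The source may report more compounds than this note shows. Statements on the series, on what has been measured and on what is new or still open speak of the compounds shown alone.

Measured so far in a functional assay on Huh-7 cells (Homo sapiens) for inhibition, read by MTT assay, with a stated time of 48 h; a lower number here means a stronger inhibitor, a higher number a weaker inhibitor:
Compound 2 `COc1ccc2c(=O)c(/C=C/C(=O)Nc3cc(C)ccc3C)coc2c1` gives 11100 nM.
Compound 1 `COc1ccc2c(=O)c(/C=C/C(=O)Nc3cccc(Cl)c3)coc2c1` gives > 100000 nM, which is a limit of the assay, not a number.
Compound 3 `Cc1ccc(CNC(=O)/C=C/c2coc3cc(O)ccc3c2=O)cc1` gives > 100000 nM, also a limit rather than a number.

Within the data shown here, compound 2 therefore stands as the only plain number here; the other two values sit at the limit of > 100000 nM in this assay, at which 2 of the 3 values shown sit. Compound 4 `COc1ccc2c(=O)c(/C=C/C(=O)NCc3ccc(F)cc3)coc2c1` has not yet been measured. It differs from compound 2 in one place: 4-fluorobenzyl in place of 2,5-dimethylphenyl on an amide-type nitrogen. Among the measured compounds shown here, the only measured step at the amide-type nitrogen, an at least 9.0-fold lower number from compound 1 to compound 2 (0.95 log units; beyond the scatter), shows that this position can move the result at least modestly. Compound 3, which also carries a benzyl-type group, reaches only a limit. Compound 4 is therefore expected to come out weaker, giving an estimated 5.4-fold higher number from compound 2 to compound 4 (0.73 log units; beyond the scatter), with a fair chance of a limit. The value of compound 4 in this assay is estimated at 60000 nM, between 15000 nM and 200000 nM.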

Compound 4, half-maximal inhibitory concentration: 21000 nM
Compound 4: middle estimate off by 2.9-fold (0.46 log units), on the high side, within the range that was stated.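

In this assay, the amide-type nitrogen accepts a 4-fluorobenzyl group as well as a 2,5-dimethylphenyl group, and the two cannot be told apart, with a 1.9-fold higher number from compound 2 to compound 4 (0.28 log units; within the scatter). The 3-chlorophenyl group of compound 1 stands apart from both, with an at least 4.7-fold lower number from compound 1 to compound 4 (0.67 log units; beyond the scatter), so a measurable value at this position is not confined to a group of the phenyl type. The top of the scale remains unresolved: the limit of > 100000 nM in this assay, at which 2 of the 4 values shown sit.

From the compounds shown here alone, whether an amine or a carboxylic acid on the benzyl ring, or a longer chain on the amide-type nitrogen, would give a lower number stays open.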